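Hydroxynaphthyl Replaces Nitrophenyl on the Shared Core

The source may hold more compounds than are shown below. What is called first, only, known or untested is meant among the compounds shown, and "the series" means these compounds.

compound 1 `COc1ccc(C2C(C#N)=C(N)N(c3ccc(S(N)(=O)=O)cc3)C3=C2C(=O)CCC3)cc1` — 30%
compound 2 `COc1cc(CC2C(C#N)=C(N)N(c3ccc(S(N)(=O)=O)cc3)C3=C2C(=O)CCC3)ccc1O` — 0%
compound 3 `N#CC1=C(N)N(c2ccc(S(N)(=O)=O)cc2)C2=C(C(=O)CCC2)C1c1ccc([N+](=O)[O-])cc1` — 85%

Of the compounds shown here, three with one shared core have been measured in a functional assay on Ehrlich cells (Mus musculus) for antiproliferative activity, read by trypan blue exclusion, with a stated time of 2 h, tested at 10 ug/mL; a lower number here means a weaker effect, a higher number a stronger effect of the compound at the concentration tested. Compound 3 stands highest of the three numbers. Its nearest neighbour is compound 1, with the step of a number 55 percentage points higher from compound 1 to compound 3 (beyond the scatter), and its furthest is compound 2, with the step of a number 85 percentage points higher from compound 2 to compound 3 (beyond the scatter). Among the compounds with values here, both steps are large and both lead to the one compound that carries a nitro group; compound 1 and compound 2, which lack it, give the two lower numbers.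

Compound 4 `N#CC1=C(N)N(c2ccc(S(N)(=O)=O)cc2)C2=C(C(=O)CCC2)C1c1c(O)ccc2ccccc12` differs from compound 3 in a single place: 2-hydroxynaphthalen-1-yl in place of 4-nitrophenyl on a saturated ring carbon. Within the data shown here, no measured step involves the 2-hydroxynaphthalen-1-yl group, so the only steps that bear on the change are those into compound 3 itself, a number 55 percentage points higher from compound 1 to compound 3 (beyond the scatter) and a number 85 percentage points higher from compound 2 to compound 3 (beyond the scatter). Both suggest that the high number of compound 3 goes with the 4-nitrophenyl group, which compound 4 loses. A downward step beyond the scatter is therefore expected, a number 50 percentage points lower from compound 3 to compound 4 (beyond the scatter), though with a wide range since the entering group has no precedent among these compounds. Compound 4 is estimated to give 35% in this assay, between 5% and 70%.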

Compound 4, a percentage reported as activity, at one concentration (the size of the read-out at that concentration, not a potency): 0%
For compound 4 the middle estimate is 35 percentage points above the measured one, outside the stated range (below it).
By their numbers in this assay, from the lowest: compounds 2 and 4 (each within the scatter of the next); then compound 1; then compound 3.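

In this assay the 2-hydroxynaphthalen-1-yl group on the saturated ring carbon keeps none of what the 4-nitrophenyl group gave, a change read as a number 85 percentage points lower from compound 3 to compound 4 (beyond the scatter). Losing the nitro group alone does not set how low the number goes, since the series shows a number 30 percentage points lower from compound 1 to compound 4 (beyond the scatter), while the comparison with the benzyl-linked compound shows no change at the digits printed from compound 2 to compound 4 (within the scatter); among these four compounds, the two whose aromatic group carries a hydroxyl give the two lowest numbers, and no compound goes against this. Nothing available explains why the position responds in this way.

The compounds shown leave open whether the hydroxyl or the second aromatic ring of the entering group goes with the low number, a question that plain naphthalen-1-yl and 4-hydroxyphenyl at this carbon would separate. They also leave open whether the high number of compound 3 needs the nitro group itself or would persist with another group in its place, such as a 4-cyanophenyl or a 4-chlorophenyl group.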